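The source may report more compounds than this note shows. Statements on the series, on what has been measured and on what is new or still open speak of the compounds shown alone.

Working notes on the series sharing the core of compound 1, `N=C(N)NCCC[C@H](NC(=O)CN(c1nc(Cl)nc2[nH]cnc12)C1CC1)C(=O)O`. In a functional assay on the whole organism (Tail, strain ICR) with Mus musculus as the target, in the tail flick test, with a stated time of 60 min, at a dose of 25 umol/kg by the oral route (a lower number here means a weaker effect, a higher number a stronger effect of the compound at the dose given), compound 1 gives 51%. Compound 2, `C[C@@H](O)[C@H](NC(=O)CN(c1nc(Cl)nc2[nH]cnc12)C1CC1)C(=O)O`, gives 30.1% in this assay, and compound 3, `O=C(O)C[C@H](NC(=O)CN(c1nc(Cl)nc2[nH]cnc12)C1CC1)C(=O)O`, gives 38.9%. Among these three numbers compound 3 stands second highest; the two steps leading to it read a number 8.8 percentage points higher from compound 2 to compound 3 (within the scatter) and a number 12.1 percentage points lower from compound 1 to compound 3 (beyond the scatter). The steps recorded so far all leave the core untouched and vary only the side chain on the saturated chain carbon: a number 20.9 percentage points lower from compound 1 to compound 2 (beyond the scatter) and a number 12.1 percentage points lower from compound 1 to compound 3 (beyond the scatter) are both modest losses against compound 1, and the two smaller side chains sit within the scatter of each other.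

Compound 4, `CC(C)C[C@H](NC(=O)CN(c1nc(Cl)nc2[nH]cnc12)C1CC1)C(=O)O`, differs from compound 3 thus: isopropyl in place of carboxy on a saturated chain carbon, two bonds along the chain from an amide-type nitrogen and a carbonyl carbon. Read one bond further out, this is carboxymethyl going to isobutyl. Within the data shown here, no measured step swaps a hydrogen-bond donor and acceptor group for a group carrying neither, so the bearing of the earlier steps is indirect; they only show that side-chain changes here move the activity modestly, not by large amounts. For compound 4 an estimated step of a number 1.1 percentage points higher from compound 3 to compound 4 (within the scatter) is therefore expected, not beyond the scatter in either direction. The expected read-out for compound 4 in this assay is 40%, in the range 22% to 58%.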

Compound 4, a percentage reported as activity, at one dose (the size of the read-out at that dose, not a potency): 36.4%
For compound 4 the middle estimate is 3.6 percentage points above the measured one; low and high end bracket the measured number.
By their numbers in this assay, from the lowest: compounds 2, 4 and 3 (each within the scatter of the next); then compound 1.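

In this assay, isopropyl in place of carboxy, on a saturated chain carbon two bonds along the chain from an amide-type nitrogen and a carbonyl carbon, gives a number 2.5 percentage points lower from compound 3 to compound 4 (within the scatter) even though the hydrogen-bond donor and acceptor of the carboxy group leave with it. Isobutyl in place of 1-hydroxyethyl likewise gives a number 6.3 percentage points higher from compound 2 to compound 4 (within the scatter) and does not separate these side chains, which now include one with no hydrogen-bond donor or acceptor in the part exchanged. Compound 1 stays apart from this group, with a number 14.6 percentage points lower from compound 1 to compound 4 (beyond the scatter) as its third step beyond the scatter.

Open, as far as these compounds go, is whether a simple amine at the end of the side chain, or a longer chain carrying a carboxylic acid, would come close to compound 1 or stay level with compounds 2, 3 and 4. Nothing at hand accounts for the standing of compound 1.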